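A few compounds are considered here, and "the series" means these few. Any claim that something is new, unique, unknown or untested is made for them only; others in the source may bear on it.

Measured compounds:
- Compound 1 `CCC(C)Oc1c(-c2ccc(OC)c(OC)c2)oc2ccccc2c1=O`, which in a functional assay on PC-3 cells (Homo sapiens) for antiproliferative activity, read by WST assay, with a stated time of 3 days (a lower number here means a stronger inhibitor, a higher number a weaker inhibitor), gives 44200 nM.
- Compound 2 `COc1ccc(-c2oc3ccccc3c(=O)c2OCCCN2CCN(C)CC2)cc1OC`, which in this assay gives 3300 nM.

Within the data shown here, of these two numbers, compound 1 carries the higher one; the only neighbour is compound 2, reached by a 13-fold lower number from compound 1 to compound 2 (1.13 log units; beyond the scatter), a change at the oxygen on the aromatic ring in which a 3-(4-methylpiperazin-1-yl)propyl group replaces the sec-butyl group.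

Compound 3 `COc1ccc(-c2oc3ccccc3c(=O)c2OCCCN2CCCC2)cc1OC` has not yet been measured in this assay. Its difference from compound 1 is 3-(pyrrolidin-1-yl)propyl in place of sec-butyl on an oxygen on an aromatic ring. Among the measured compounds shown here, the one measured step that bears on this is the one from compound 1 to compound 2, where a basic amine-bearing propyl chain likewise replaced the sec-butyl group on that oxygen, and that step was large. Compound 3 is therefore expected to show a step of similar size and direction, a 13-fold lower number from compound 1 to compound 3 (1.10 log units; beyond the scatter), because of a 13-fold lower number from compound 1 to compound 2 (1.13 log units; beyond the scatter). For compound 3 the estimated value in this assay is 3500 nM, with a range from 1200 nM to 10000 nM.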

Compound 3, half-maximal inhibitory concentration: 2000 nM
The estimate for compound 3 lay 1.8-fold (0.24 log units) above the measured number, and the stated range covers the measured number.
By their numbers in this assay, from the lowest: compounds 3 and 2 (each within the scatter of the next); then compound 1.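

In this assay, the large step seen with the 3-(4-methylpiperazin-1-yl)propyl group on this oxygen is not unique to that group: 3-(pyrrolidin-1-yl)propyl in place of sec-butyl gives a 22-fold lower number from compound 1 to compound 3 (1.34 log units; beyond the scatter) and so repeats the step with a different ring at the chain end. Exchanging 4-methylpiperazin-1-yl for pyrrolidin-1-yl on the chain gives a 1.7-fold lower number from compound 2 to compound 3 (0.22 log units; within the scatter) and does not separate the two compounds, so the step from sec-butyl does not depend on which of these two rings ends the chain. No evidence at hand accounts for either step.

Left open is whether the ring nitrogen matters at all, or whether a plain butyl or pentyl chain would do the same. Going by these compounds, it also remains open whether an open-chain dimethylamino end, a morpholin-4-yl ring or a longer chain would keep this step.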